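Turning One Stereocentre in a Cytotoxicity Test

A few compounds are considered here, and "the series" means these few. Any claim that something is new, unique, unknown or untested is made for them only; others in the source may bear on it.

This study asks whether a compound harms mouse cells grown in culture, measured by a functional assay on J774 cells (Mus musculus) for cytotoxicity, with a stated time of 48 h; on this read-out lower numbers stand for stronger inhibition and higher numbers for weaker inhibition. Compound 3 `CC(C)(C)OC(=O)NCC(=O)N1CCC[C@H](C(=O)N2[C@H](C(=O)OCc3ccccc3)[C@H]2C(=O)OCc2ccccc2)C1` gives > 100000 nM in this assay. That entry is a limit of the assay and not an exact number. It is also the only result available so far, as the limit of > 100000 nM in this assay, at which 1 of the 3 values shown sits, makes plain. Compound 1 `CC(C)C[C@H](NC(=O)OC(C)(C)C)C(=O)N1CCC[C@H](C(=O)N2[C@H](C(=O)O)[C@H]2C(=O)O)C1` has the entry "not determined" (no result reported) in this assay. Compound 2 `CC(C)(C)OC(=O)NCC(=O)N1CCC[C@H](C(=O)N2[C@H](C(=O)O)[C@H]2C(=O)O)C1` has the entry "not determined" (no result reported) in this assay. Among the compounds with values here, these two compounds therefore offer no comparison, and no step between measured compounds exists to serve as a guide.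

The next candidate is compound 4 `CC(C)(C)OC(=O)NCC(=O)N1CCC[C@@H](C(=O)N2[C@H](C(=O)OCc3ccccc3)[C@H]2C(=O)OCc2ccccc2)C1`. Its difference from compound 3 is the two compounds have the same atoms and bonds and differ only in configuration as drawn: 1 of 3 stereo elements differ; a stereocentre at a saturated ring carbon is drawn S in compound 3 and R in compound 4. Put simply, the same atoms stay joined in the same order, and the change lies only in how they are arranged in space at that one carbon.

With so little to go on, no step beyond the usual scatter is expected in this assay, and no direction can be favoured. This expectation rests solely on the limit of compound 3, > 100000 nM. The estimated change is a number no higher from compound 3 to compound 4 (the limit leaves the size open). For compound 4, the expected value is 100000 nM. The estimated range for compound 4 runs from 50000 nM to 200000 nM.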

Compound 4, half-maximal inhibitory concentration: > 100000 nM
Compound 4: a limit, no number; the forecaster's own chance of this, stated with the estimate: 85%; the middle value lies on the limit itself.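

Compound 3 and compound 4 both end at the same limit of the assay, not at a number, so no step between them can be read: the limit of > 100000 nM in this assay, at which 2 of the 4 values shown sit.

The compounds shown leave open whether drawing this saturated ring carbon as S or R changes the result at all, and at what concentration either compound would reach half-maximal inhibition.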